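This account rests on a few compounds, and the source may have more. Where it says the series, first, only, none or still open, it means among the compounds named here.

Three compounds share one core and differ only in the group on the sulfonamide nitrogen. Compound 1 `CNS(=O)(=O)c1ccc2c(c1)C(n1ccccc1=O)=CC(C)(C)O2` gives 17.8 nM in a functional assay with Rattus norvegicus as the target (on this read-out higher numbers stand for an effect only at larger amounts of compound and lower numbers for an effect already at smaller amounts), which places it second highest of the three numbers. Compound 3 `CN(c1ccccc1)S(=O)(=O)c1ccc2c(c1)C(n1ccccc1=O)=CC(C)(C)O2` gives 1.74 nM, and compound 2 `CC1(C)C=C(n2ccccc2=O)c2cc(S(=O)(=O)Nc3ccc(C#N)cc3)ccc2O1` gives 263 nM. The change to compound 4 `CC1(C)C=C(n2ccccc2=O)c2cc(S(=O)(=O)NC(=O)Nc3ccccc3)ccc2O1` is phenylcarbamoyl in place of methyl on a sulfonamide nitrogen. Among the measured compounds shown here, two measured steps bear on it. Replacing the hydrogen on the sulfonamide nitrogen with phenyl gave a 10-fold lower number from compound 1 to compound 3 (1.01 log units; beyond the scatter), whereas putting 4-cyanophenyl in place of methyl there gave a 15-fold higher number from compound 1 to compound 2 (1.17 log units; beyond the scatter). So a phenyl added to this nitrogen can go either way, and compound 4 keeps a hydrogen-bond donor on the nitrogen as compound 2 does, which went with the weaker number. On balance a modestly higher number than compound 1 is expected, with wide uncertainty. The expected step is a 3.4-fold higher number from compound 1 to compound 4 (0.53 log units; beyond the scatter). Compound 4 is therefore estimated at 60 nM, within a range from 10 nM to 400 nM.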

Compound 4, half-maximal effective concentration: 1410 nM
Compound 4: middle estimate off by 24-fold (1.37 log units), on the low side; the measured number lies above the stated range.
By their numbers in this assay, from the lowest: compound 3; then compound 1; then compound 2; then compound 4.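

Putting phenylcarbamoyl on the sulfonamide nitrogen gives the highest number of the series, with a 79-fold higher number from compound 1 to compound 4 (1.90 log units; beyond the scatter) and an 810-fold higher number from compound 3 to compound 4 (2.91 log units; beyond the scatter), and even compared with the earlier high point there is a 5.4-fold higher number from compound 2 to compound 4 (0.73 log units; beyond the scatter). Compounds 2 and 4 both keep a hydrogen on this nitrogen and carry an aromatic ring further out, and they give the two highest numbers, whereas compound 3, with methyl and phenyl on the nitrogen and no such hydrogen, gives the lowest; compound 1 also keeps that hydrogen yet sits in the middle, so the hydrogen alone does not set the number. No measurement shown explains these differences.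

Going by these compounds, it remains open how an acetyl group on this nitrogen, which has the carbonyl but no phenyl ring, or a benzyl group, which has the ring but no carbonyl, would compare. Also open, on these data alone, is whether a methyl on the sulfonamide nitrogen of compound 4, replacing its hydrogen, would bring the number down.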